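Propyl in Place of Isopropyl, Tried on a Second Core

This account rests on a few compounds, and the source may have more. Where it says the series, first, only, none or still open, it means among the compounds named here.

Compound 1 `CC(C)C1Cc2cc(OCc3ccc(-c4nn[nH]n4)cc3)c(Cl)c(Cl)c2C1=O` and compound 2 `CCCC1Cc2cc(OCc3ccc(-c4nn[nH]n4)cc3)c(Cl)c(Cl)c2C1=O` share one core and differ only in propyl in place of isopropyl on a saturated ring carbon. In an assay on isolated protein for binding affinity to metabotropic glutamate receptor 2 (Homo sapiens) (on this read-out lower numbers stand for an effect already at smaller amounts and higher numbers for an effect only at larger amounts of compound), compound 1 gives 195 nM, and compound 2 gives 282 nM, so the change made a 1.4-fold higher number from compound 1 to compound 2 (0.16 log units; within the scatter).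

Compound 3 `CC(C)C1Cc2cc(OCc3cccc(CSc4ccncc4)c3)c(Cl)c(Cl)c2C1=O` carries a different core; how the cores of compound 3 and compound 1 differ is not broken down here. In this assay compound 3 gives 839 nM, the highest of the three numbers.

Compound 4 `CCCC1Cc2cc(OCc3cccc(CSc4ccncc4)c3)c(Cl)c(Cl)c2C1=O` is not yet measured. It differs from compound 3 in propyl in place of isopropyl on a saturated ring carbon, the same change as that from compound 1 to compound 2, at the same kind of place. Because the earlier step was a 1.4-fold higher number from compound 1 to compound 2 (0.16 log units; within the scatter), the step is expected to be small, a 1.3-fold higher number from compound 3 to compound 4 (0.12 log units; within the scatter). Compound 4 is therefore estimated at 1100 nM in this assay, expected between 500 nM and 2500 nM.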

Compound 4, half-maximal effective concentration: 186 nM
For compound 4 the middle estimate is 5.9-fold (0.77 log units) above the measured one, outside the stated range (below it).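

In this assay, putting propyl in place of isopropyl on a saturated ring carbon gave a 4.5-fold lower number from compound 3 to compound 4 (0.65 log units; beyond the scatter). The change therefore did not carry over from one core to the other with the same size: the same change on two cores in this assay, a 1.4-fold higher number (0.16 log units; within the scatter) from compound 1 to compound 2 and a 4.5-fold lower number (0.65 log units; beyond the scatter) from compound 3 to compound 4, 6.5-fold (0.81 log units) apart, beyond the scatter of two such steps. This shows that, in this series, the step seen on the core of compound 1 did not predict the step on the core of compound 3, but it does not show which feature of the two cores accounts for the gap, and two cores give no rule for any others.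

The compounds shown leave open how a longer chain, such as butyl, would behave on the same saturated ring carbon. They also leave open whether an ethyl group there would show the same gap between the two cores.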